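Aryl urea variation in MDA-MB-468 growth inhibition

The source may report more compounds than this note shows. Statements on the series, on what has been measured and on what is new or still open speak of the compounds shown alone.

Measured so far:
compound 1 `O=C(Nc1cccc(-n2cc(-c3ccncc3)c(-c3ccc(Cl)c(O)c3)n2)c1)Nc1cccc(C(F)(F)F)c1`: > 32500 nM
compound 2 `COc1cc(-c2nn(-c3cccc(NC(=O)Nc4cccc(C(F)(F)F)c4)c3)cc2-c2ccncc2)ccc1Cl`: 50000 nM
compound 3 `O=C(Nc1cccc(-n2cc(-c3ccncc3)c(-c3ccc(Cl)c(O)c3)n2)c1)Nc1cc(C(F)(F)F)cc(C(F)(F)F)c1`: 37100 nM

In a functional assay on MDA-MB-468 cells (Homo sapiens) for inhibition, read by sulforhodamine B assay, with a stated time of 48 h (a higher number here means that more compound is tolerated, a lower number that less compound is tolerated), compound 1 gives only a limit, > 32500 nM. Compound 2 gives 50000 nM. Compound 3 gives 37100 nM. The steps a step that the limit leaves unreadable from compound 1 to compound 2 and a step that the limit leaves unreadable from compound 1 to compound 3 cannot be sized because of the limit of > 32500 nM in this assay, at which 1 of the 3 values shown sits. Compound 4 `O=C(Nc1cccc(-n2cc(-c3ccncc3)c(-c3ccc(Cl)c(O)c3)n2)c1)Nc1ccc(Cl)c(C(F)(F)F)c1` differs from compound 1 by chloro in place of hydrogen on an aromatic carbon. Among the measured compounds shown here, no measured step covers this change, and the two steps that start from compound 1 are both hidden by its limit; all three measured values sit in the same upper region of this assay. Compound 4 is therefore expected to remain in that region, with a step that the limit leaves unreadable from compound 1 to compound 4 as the expected step, no step beyond the scatter. The estimate for compound 4 is 40000 nM, range 20000 nM to 80000 nM.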

Compound 4, concentration lethal to 50% of the cells: > 32500 nM
Compound 4 gave a limit, no number (the forecaster's own chance of this, stated with the estimate: 45%); the middle value lies beyond the limit too.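

Compound 1 and compound 4 both carry only a limit, so no step between them can be read: the limit of > 32500 nM in this assay, at which 2 of the 4 values shown sit.

As far as these compounds go, whether chloro in place of hydrogen changes the value at all remains open.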